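Benzyl Carbamate in Place of a Sulfonyl Carbamate

The compounds below may be only part of what the source reports. "The series", "measured", "known", "first", "only" and "open" are said of these compounds alone.

Measured so far:
Compound 1 `CC(C)=CCC/C(C)=C/CC/C(C)=C/CC[C@]1(C)CCc2cc(OC(=O)NS(=O)(=O)c3ccc(Cl)cc3)cc(C)c2O1`: in a functional assay on MDA-MB-231 cells (Homo sapiens) for antiproliferative activity, read by MTT assay, with a stated time of 96 h (on this read-out lower numbers stand for stronger inhibition and higher numbers for weaker inhibition), compound 1 gives > 10000 nM, which is a limit of the assay rather than a number.
Compound 2 `CC(C)=CCC/C(C)=C/CC/C(C)=C/CC[C@]1(C)CCc2c(C)c(OC(=O)NCc3ccccc3)c(C)c(C)c2O1`: in this assay compound 2 gives 7200 nM.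
Compound 3 `CC(C)=CCC/C(C)=C/CC/C(C)=C/CC[C@]1(C)CCc2cc(OC(=O)NS(=O)(=O)c3ccc(Cl)cc3)c(C)c(C)c2O1`: in this assay compound 3 gives > 10000 nM, again a limit and not a number.

Compound 1 therefore stands at the limit of > 10000 nM in this assay, at which 2 of the 3 values shown sit. Within the data shown here, the only step measured between two compounds that differ in a single place, a step that the two limits leave unreadable from compound 1 to compound 3, yields no readable size.

Compound 4 `CC(C)=CCC/C(C)=C/CC/C(C)=C/CC[C@]1(C)CCc2cc(OC(=O)NCc3ccccc3)cc(C)c2O1` differs from compound 1 by benzyl in place of (4-chlorophenyl)sulfonyl on an amide-type nitrogen. Among the measured compounds shown here, no measured step follows this same exchange on a matched pair, so it has no direct precedent here. Compound 2, which carries the benzyl group on a core bearing more methyl groups, does return a number, 7200 nM. Compound 3, its sulfonyl counterpart in spirit though not a one-place partner, remains at the limit. That contrast is the only hint available.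

Compound 4 is expected to land near 9000 nM, with a range from 4000 nM to 20000 nM, and with a real chance of returning only a limit. The expected step is an at least 1.1-fold lower number from compound 1 to compound 4 (0.04 log units; that floor lies within the scatter), read from a starting point that is itself only a limit.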

Compound 4, half-maximal inhibitory concentration: > 10000 nM
Compound 4: a limit, no number; the forecaster's own chance of this, stated with the estimate: 45%; middle value at least 1.1-fold (0.04 log units) from the limit.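

Compound 4 joins the compounds that return a limit of the assay rather than a number: the limit of > 10000 nM in this assay, at which 3 of the 4 values shown sit. Compound 1 and compound 4 are both limits, and the step between them cannot be read. The compounds shown leave open whether benzyl in place of (4-chlorophenyl)sulfonyl on an amide-type nitrogen changes antiproliferative activity on this core at all.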